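Removing the Aromatic Methyl from a Bromophenyl Urea Series

This account rests on a few compounds, and the source may have more. Where it says the series, first, only, none or still open, it means among the compounds named here.

Of the compounds shown here, three have been measured in a functional assay for antagonist activity at transient receptor potential cation channel subfamily V member 1 (Rattus norvegicus), read by FLIPR; a lower number here means a less potent compound, a higher number a more potent compound, by a factor of ten per unit of this negative logarithm. Compound 1, `Cc1cccc2c1CCN2CCNC(=O)Nc1ccccc1Br`, gives 7.4 in this assay. Compound 2, `O=C(Nc1ccccc1Br)N[C@@H]1CCN(c2cccc(C(F)(F)F)n2)C1`, gives 7.2, and compound 3, `O=C(Nc1ccccc1Br)N[C@@H]1CCN(c2ccc(Br)cn2)C1`, gives 7.2. Compound 1 has the highest of the three numbers, but both of its neighbours lie within the usual scatter of repeated measurements, so the three cannot be ranked against one another on these data alone.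

Compound 4, `O=C(NCCN1CCc2ccccc21)Nc1ccccc1Br`, has not yet been measured. It differs from compound 1 in a single place: hydrogen in place of methyl on an aromatic carbon. Among the compounds with values here, no step between two measured compounds is available to show how much this kind of change is worth here, so what follows rests only on the small size of the change and on the closeness of the three numbers already in hand.

For compound 4 the step from compound 1 is expected to be small, with the estimated a number 0.20 log units lower from compound 1 to compound 4 (within the scatter) lying within the scatter rather than beyond it. Compound 4 is accordingly expected to give about 7.2 in this assay, between 6.7 and 7.7.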

Compound 4, negative logarithm of the antagonist equilibrium constant: 6.8
The estimate for compound 4 lay 0.40 log units above the measured number, and the stated range covers the measured number.
By their numbers in this assay, from the lowest: compound 4; then compounds 2, 3 and 1 (each within the scatter of the next).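

In this assay, within the data shown here, the methyl on the aromatic carbon proves to matter, with a number 0.60 log units lower from compound 1 to compound 4 (beyond the scatter) as the only step here that isolates a single change. That change takes away one carbon and adds no ring, hydrogen-bond donor, hydrogen-bond acceptor or charge, so a single heavy atom at this place, ortho to a fused ring and meta to a fused ring, is enough to move the number beyond the scatter. Nothing available explains why the number falls.

On these data alone, whether the methyl is unique at this carbon remains open, since an ethyl group, a chlorine or a methoxy group there would show whether other substituents match it. Also open, as far as these compounds go, is whether a methyl on the other aromatic carbons of that ring would be worth a similar step.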